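Replacing an Ester With an Acetamide on a Shared Core

The source may report more compounds than this note shows. Statements on the series, on what has been measured and on what is new or still open speak of the compounds shown alone.

Compound 1 `CCCCOC(=O)c1cccc(-c2ccc(OCC)cc2)c1` has the higher of the two measured numbers in an assay on COS-7 cells for inhibition of patatin-like phospholipase domain-containing protein 2 (Mus musculus), tested at 200 uM (on this read-out higher numbers stand for more inhibition at the one concentration tested (going by the name of the read-out) and lower numbers for less inhibition), where compound 1 gives 61%. Among the compounds with values here, the only neighbour is compound 2 `CCOc1ccc(-c2cccc(C(=O)OCCOCCOC)c2)cc1`, which in this assay gives 43%; the single measured step is a number 18 percentage points lower from compound 1 to compound 2 (beyond the scatter), so lengthening the ester chain with a 2-methoxyethoxy group lowers the inhibition in this assay by a modest amount.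

Compound 3 `CCOc1ccc(-c2cccc(NC(C)=O)c2)cc1` changes compound 1 in one place: acetamido in place of butoxycarbonyl on an aromatic carbon. The whole ester is removed and a small amide with one hydrogen-bond donor takes its place. Within the data shown here, no measured step covers this kind of exchange; the step from compound 1 to compound 2 only reshapes the ester chain and leaves the carbonyl and both oxygens in place, so it bears on compound 3 only loosely, hinting that an alteration at the ester end of the molecule goes with a modestly lower number in this assay.

For compound 3 a modest decrease is therefore expected, a number 16 percentage points lower from compound 1 to compound 3 (beyond the scatter), with wide uncertainty. The expected value for compound 3 in this assay is 45%, within a range from 15% to 75%.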

Compound 3, a percentage reported as inhibition, at one concentration (the size of the read-out at that concentration, not a potency): 52%
Beside the measured number, compound 3's estimate is 7 percentage points below it; the range from low to high includes it.
By their numbers in this assay, from the lowest: compounds 2, 3 and 1 (each within the scatter of the next, the first and the last beyond it).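

Putting acetamido in place of butoxycarbonyl on this aromatic carbon gives a number 9 percentage points lower from compound 1 to compound 3 (within the scatter) in this assay and so the reading stays within the usual scatter even though the whole ester has gone. The earlier pair only reshaped the ester chain and kept its carbonyl and both oxygens, whereas compound 3 shows that this position accepts a smaller group of a different type, one that carries a hydrogen-bond donor where butoxycarbonyl has none, with no clear difference from compound 1 at the one concentration tested. Nothing measured here gives a reason for this result.

Still open, as far as these compounds go, is whether the reading depends on the carbonyl or on the amide hydrogen of acetamido, a question that a plain amine or a carboxylic acid on the same aromatic carbon would help to answer. Also open, from the compounds shown here alone, is how much room the amide side allows, which a longer chain on the amide carbonyl, such as butanamido, would begin to test.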